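Adding a methoxy group to a weak compound

The source may hold more compounds than are shown below. What is called first, only, known or untested is meant among the compounds shown, and "the series" means these compounds.

Compound 1 `COc1cc(C#N)ccc1OCc1nnc(-c2ccc(F)cc2)o1`: 10300 nM
Compound 2 `N#Cc1ccc(OCc2nnc(-c3ccc(F)cc3)o2)cc1F`: 20500 nM
Compound 3 `c1ccc(-c2nnc(COc3ccc(-c4nnco4)cc3)o2)cc1`: > 50000 nM, a limit of the assay and not a number

All three were tested in a functional assay on MCF7 cells (Homo sapiens) for cytotoxicity, read by MTT assay, with a stated time of 48 h; on this read-out lower numbers stand for stronger inhibition and higher numbers for weaker inhibition. Compound 3 has no exact value there, only (the limit of > 50000 nM in this assay, at which 1 of the 3 values shown sits). Compounds 1 and 2 give actual numbers that lie within the usual scatter of each other. Among the measured compounds shown here, neither of them differs from compound 3 in just one place, so no measured pair shows directly what the next change does.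

Compound 4 `COc1ccc(-c2nnc(COc3ccc(-c4nnco4)cc3)o2)cc1` has not been measured yet. It carries methoxy in place of hydrogen on an aromatic carbon, which turns phenyl to 4-methoxyphenyl: methoxy in place of hydrogen on an aromatic carbon. For the measured compounds named here, with no measured step to lean on, only a small move toward stronger inhibition is expected, and perhaps none beyond the scatter. The expected change is an at least 1.2-fold lower number from compound 3 to compound 4 (0.09 log units; that floor lies within the scatter). The assay may again report only a limit. For compound 4 the estimate is 40000 nM, with an expected range from 15000 nM to 90000 nM.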

Compound 4, half-maximal inhibitory concentration: 31200 nM
Beside the measured number, compound 4's estimate is 1.3-fold (0.11 log units) above it; measured number inside the range.
By their numbers in this assay, from the lowest: compounds 1, 2 and 4 (each within the scatter of the next, the first and the last beyond it). At a limit, above all of these: compound 3.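

In this assay, among the compounds shown here, methoxy in place of hydrogen on an aromatic carbon, para to a large group, gives the first step that can be read in this set: an at least 1.6-fold lower number from compound 3 to compound 4 (0.20 log units; that floor lies within the scatter). Compound 3 stands at a limit and not at a number, so this step gives only a floor, and the real change could be larger: the limit of > 50000 nM in this assay, at which 1 of the 4 values shown sits. Compound 4, at 31200 nM, gives this core an actual number at this position, against which a further change there can be read.

The compounds shown do not tell whether another group at this position, such as a hydroxyl, an amine or a longer chain like ethoxy, would give a different number. They also leave open what methoxy does on the other carbons of this ring.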